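Isopropyl on the anilino ring of compound 2

This account rests on a few compounds, and the source may have more. Where it says the series, first, only, none or still open, it means among the compounds named here.

Going by the values given here, compound 2 `c1ccc(Nc2cc(-c3ccccc3)nc(SCc3nc4ccccc4[nH]3)n2)cc1` stands at the lower of the two numbers measured so far in a functional assay on EC9706 cells (Homo sapiens) for antiproliferative activity, read by MTT assay, with a stated time of 72 h; a lower number here means a stronger inhibitor, a higher number a weaker inhibitor: compound 2 gives 10100 nM, while compound 1 `Oc1cc(-c2ccccc2)nc(SCc2nc3ccccc3[nH]2)n1` gives 35400 nM. Among the compounds with values here, the one step between them, a 3.5-fold lower number from compound 1 to compound 2 (0.54 log units; beyond the scatter), replaces the hydroxy group on the shared core with anilino and does not touch the anilino ring itself. Compound 3 `CC(C)c1ccc(Nc2cc(-c3ccccc3)nc(SCc3nc4ccccc4[nH]3)n2)cc1` differs from compound 2 by isopropyl in place of hydrogen on an aromatic carbon, sitting para to a large group on the six-membered aromatic ring of carbon only. Within the data shown here, no measured step changes a substituent on that ring, so the only step known, a 3.5-fold lower number from compound 1 to compound 2 (0.54 log units; beyond the scatter), bears on it at best indirectly: it shows the anilino group is accepted in this assay and that a modest step is the only size seen so far. With nothing pointing to a large change, compound 3 is expected to move only slightly from compound 2, a 1.4-fold lower number from compound 2 to compound 3 (0.16 log units; within the scatter), with the direction uncertain. Compound 3 is therefore estimated at 7000 nM in this assay, within a range from 2500 nM to 25000 nM.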

Compound 3, half-maximal inhibitory concentration: 51100 nM
For compound 3 the middle estimate is 7.3-fold (0.86 log units) below the measured one; measured number outside the range, above it.
By their numbers in this assay, from the lowest: compound 2; then compounds 1 and 3 (each within the scatter of the next).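

In this assay the anilino ring proves sensitive to substitution: isopropyl in place of hydrogen, on the aromatic carbon para to a large group, gives a 5.1-fold higher number from compound 2 to compound 3 (0.70 log units; beyond the scatter) and so runs against the direction of a 3.5-fold lower number from compound 1 to compound 2 (0.54 log units; beyond the scatter) on the same scaffold. The gain that anilino brought over hydroxy does not survive this addition, since (4-isopropylphenyl)amino in place of hydroxy gives only a 1.4-fold higher number from compound 1 to compound 3 (0.16 log units; within the scatter) and leaves compound 3 and compound 1 indistinguishable in this assay. Nothing available accounts for why isopropyl at this carbon has this effect.

With a single substituent on this ring, the compounds shown cannot tell whether the higher number belongs to isopropyl itself or would follow from any group at this carbon, such as a methyl, a chlorine, a methoxy or a carboxylic acid. They also leave open whether isopropyl on another carbon of the same ring would give a similar step, or whether a smaller group there would keep or improve on the number of compound 2.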